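The compounds below may be only part of what the source reports. "The series", "measured", "known", "first", "only" and "open" are said of these compounds alone.

Series notes. Compound 1 `O=C(NCc1ccc(NC(=O)c2cccc(F)c2N2CCCC2)cc1)OCc1cccnc1` and compound 3 `Cc1cccc(C(=O)Nc2ccc(CNC(=O)OCc3cccnc3)cc2)c1N1CCCC1` share a core and differ by methyl in place of fluoro on an aromatic carbon. Compound 2 `O=C(NCc1ccc(NC(=O)c2ccc(F)cc2N2CCCC2)cc1)OCc1cccnc1` is built from the same atoms as compound 1 joined differently; the difference between the two cores is not broken down here. Compound 4 `Cc1ccc(C(=O)Nc2ccc(CNC(=O)OCc3cccnc3)cc2)c(N2CCCC2)c1` is unmeasured and differs from compound 2 by methyl in place of fluoro on an aromatic carbon. In a toxicity assay on GES1 cells (Homo sapiens) for inhibition, read by MTT assay, with a stated time of 72 h (a higher number here means a weaker inhibitor, a lower number a stronger inhibitor), compound 1 gives > 100000 nM, a limit of the assay. Compound 3 gives > 100000 nM in this assay, again a limit. Compound 2 gives > 100000 nM in this assay, also a limit. The step that the two limits leave unreadable from compound 1 to compound 3 cannot be sized, which follows from the limit of > 100000 nM in this assay, at which 3 of the 3 values shown sit. The change from compound 2 to compound 4 is the same kind of change as that from compound 1 to compound 3, not the same: in compound 1 the fluoro sits ortho to a pyrrolidin-1-yl group and meta to a large group, in compound 2 meta to a pyrrolidin-1-yl group and para to a large group. The step that the limit leaves unreadable from compound 2 to compound 4 is expected to be small, since compound 2 sits at > 100000 nM and the measured step that the two limits leave unreadable from compound 1 to compound 3 showed no readable movement. Compound 4 is therefore estimated at 150000 nM, between 60000 nM and 400000 nM, most likely reported only as a limit.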

Compound 4, half-maximal inhibitory concentration: > 100000 nM
Compound 4: a limit, no number (the forecaster's own chance of this, stated with the estimate: 85%); the middle value does not contradict the limit.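

No new step can be read from compound 2 to compound 4, nor from any other pair, because both compounds of each pair sit at a limit: the limit of > 100000 nM in this assay, at which 4 of the 4 values shown sit.

The compounds shown leave open whether methyl in place of fluoro, or the place of either group, changes the read-out in this assay at all.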